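Fixing Two Stereocentres in a Paw Edema Series

The source may report more compounds than this note shows. Statements on the series, on what has been measured and on what is new or still open speak of the compounds shown alone.

Measured so far:
In a functional assay on the whole organism (strain Wistar) for inhibition, with Rattus norvegicus as the target, read by paw edema, with stated times of 1 h and 4 h, at a dose of 10 mg/kg by the intraperitoneal route (on this read-out higher numbers stand for more inhibition at the one dose given (going by the name of the read-out) and lower numbers for less inhibition), compound 1 `COc1cc(/C=C/C(=O)/C=C(O)/C=C/c2ccc(OC(=O)[C@@H](CCSC)NC(=O)OCc3ccccc3)c(OC)c2)ccc1OC(=O)[C@@H](CCSC)NC(=O)OCc1ccccc1` gives 94%.
In this assay compound 2 `COc1cc(/C=C/C(=O)/C=C(O)/C=C/c2ccc(OC(=O)C(C)NC(=O)OCc3ccccc3)c(OC)c2)ccc1OC(=O)C(C)NC(=O)OCc1ccccc1` gives 100%.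

Compound 2 has the higher of the two numbers, but the gap to compound 1 lies within the scatter, so the two cannot be placed in any order on these data. Compound 3 `COc1cc(/C=C/C(=O)/C=C(O)/C=C/c2ccc(OC(=O)[C@@H](C)NC(=O)OCc3ccccc3)c(OC)c2)ccc1OC(=O)[C@@H](C)NC(=O)OCc1ccccc1` is the companion to be measured next. The change from compound 2 to compound 3 is the two compounds have the same atoms and bonds; at least one stereo element is drawn with a configuration in one of them and without one in the other: 2 of 5 stereo elements differ; a stereocentre at a saturated chain carbon is drawn without a configuration in compound 2 and R in compound 3; a stereocentre at a saturated chain carbon is drawn without a configuration in compound 2 and R in compound 3. No bond is made or broken; the only difference is that the stereocentre at each saturated chain carbon, drawn without a configuration in compound 2, is drawn R in compound 3. Going by the values given here, no step between two measured compounds is available here, so the size of this move must be judged from the nature of the change alone. Because compound 2 already shows 100%, a step in this assay of no more than the scatter is expected, with no direction, and the expected step from compound 2 to compound 3 is a number 4 percentage points lower from compound 2 to compound 3 (within the scatter). Compound 3 is therefore estimated to give 96% in this assay, within a range of 86% to 100%.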

Compound 3, a percentage reported as inhibition, in the whole organism at one dose (the size of the read-out at that dose, not a potency): 100%
Estimate against measurement, compound 3: 4 percentage points below; measured number inside the range.
By their numbers in this assay, from the lowest: compounds 1, 2 and 3 (each within the scatter of the next).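

Drawing both saturated chain carbons as R gives no change at the digits printed from compound 2 to compound 3 (within the scatter) in this assay at the one dose, so the R form at these two places keeps the inhibition seen with the form drawn without a configuration. Going by these compounds alone, no bond is made or broken in this step, which makes it the only reading on configuration alone. The reading has one clear bound, and it concerns what the drawings themselves record: the fact that one of compounds 2 and 3 is drawn with a defined configuration and the other without, at the place where they differ

The data do not say whether compound 2 is a single form or a mixture, and the form with both carbons drawn S stands outside the compounds shown, so no preference for either configuration can be read here. Also open, as far as these compounds go, is how a side chain carrying a carboxylic acid or an amine, or a longer chain, at these same two carbons would read in this assay, and whether compound 2 and compound 3 would still stay together at a lower dose.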